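Hepatocyte clearance notes: amino replaces fluoro on the core

This account rests on a few compounds, and the source may have more. Where it says the series, first, only, none or still open, it means among the compounds named here.

Compound 1 `CCc1nc(N)nc2c1c(-c1ccc3oc(N)nc3c1)nn2C(C)C` in an ADME assay on cells (Hepatocyte, Homo sapiens) for metabolic stability, read by LC-MS, with a stated time of 90 min, tested at 1 uM (a higher number here means faster removal of the compound, a lower number slower removal), gives < 5 uL/min, which is a limit of the assay rather than a number.
Compound 2 `CC(C)n1nc(-c2ccc3oc(N)nc3c2)c2c(CO)nc(N)nc21` in this assay gives < 5 uL/min, again a limit of the assay.
Compound 3 `CC(C)n1nc(-c2ccc3oc(N)nc3c2)c2c(F)nc(N)nc21` in this assay gives 57 uL/min.

Compound 3 therefore stands alone with the only number shown; the other two values sit at the limit of < 5 uL/min in this assay, at which 2 of the 3 values shown sit. The step to compound 4 `CC(C)n1nc(-c2ccc3oc(N)nc3c2)c2c(N)nc(N)nc21` is amino in place of fluoro on an aromatic carbon. Among the compounds with values here, two measured steps bear on it: an at least 11-fold higher number from compound 1 to compound 3 (1.05 log units; beyond the scatter) and an at least 11-fold higher number from compound 2 to compound 3 (1.05 log units; beyond the scatter), both large and both running toward the higher number of compound 3. The step that the two limits leave unreadable from compound 1 to compound 2 cannot be sized, since both of its ends are limits. Compound 4 goes the other way from fluoro, so the expected step is a large downward one, an 8.1-fold lower number from compound 3 to compound 4 (0.91 log units; beyond the scatter), quite possibly reaching the limit again. For compound 4 the estimated value is 7 uL/min, with a range from 2.5 uL/min to 25 uL/min.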

Compound 4, intrinsic clearance in a liver preparation (reported as CLH), per the amount of preparation that the assay uses: < 5 uL/min
Compound 4: no number, only a limit; the forecaster's own chance of this, stated with the estimate: 50%; at least 1.4-fold (0.14 log units) between middle value and limit.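

At the aromatic carbon next to the ring nitrogen, amino in place of fluoro gives an at least 11-fold lower number from compound 3 to compound 4 (1.05 log units; beyond the scatter) in this assay, so the amino group joins ethyl and hydroxymethyl on the low side of compound 3. Among the four groups at this carbon, only fluoro gives a readable number, which ties the faster removal of compound 3 to fluoro rather than to the shared core. The steps among compound 1, compound 2 and compound 4 cannot be read, since all three values are limits and not numbers: the limit of < 5 uL/min in this assay, at which 3 of the 4 values shown sit.

As far as these compounds go, how ethyl, hydroxymethyl and amino rank beneath that limit stays open. Also open, from the compounds shown here alone, is whether chloro, methoxy or a plain hydrogen at this carbon would follow fluoro or fall with the other three groups.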